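The source may hold more compounds than are shown below. What is called first, only, known or untested is meant among the compounds shown, and "the series" means these compounds.

Compound 1, `C=C[C@@](C)(/C=C/c1ccc(O)c(/C=C/c2ccc(Cl)cc2)c1)CCC=C(C)C`, carries a 4-chlorophenyl group. In a functional assay on SEM cells (Homo sapiens) for cytotoxicity, with a stated time of 72 h (a higher number here means that more compound is needed for the effect, a lower number that less compound is needed), compound 1 reaches only a limit, > 36600 nM, so no number is known for it. Compound 2, `C=C[C@@](C)(/C=C/c1ccc(O)c(/C=C/c2ccc(Cl)c(Cl)c2)c1)CCC=C(C)C`, differs by chloro in place of hydrogen on an aromatic carbon. In this assay compound 2 likewise gives only a limit, > 7500 nM. The step that the two limits leave unreadable from compound 1 to compound 2 rests on the limit of > 36600 nM in this assay, at which 2 of the 3 values shown sit, and (the limit of > 7500 nM in this assay, at which 1 of the 3 values shown sits). Compound 3, `C=C[C@@](C)(/C=C/c1ccc(Nc2ccc(Cl)cc2)cc1)CCC=C(C)C`, has a different core; the difference between the two cores is not broken down here. In this assay compound 3 again shows only a limit, > 36600 nM. Compound 4, `C=C[C@@](C)(/C=C/c1ccc(Nc2ccc(Cl)c(Cl)c2)cc1)CCC=C(C)C`, is compound 3 with chloro in place of hydrogen on an aromatic carbon, the same change as from compound 1 to compound 2. Given that unreadable earlier step, the step is expected to be a number no higher from compound 3 to compound 4 (the limit leaves the size open). Compound 4 is therefore estimated at 36600 nM, between 7500 nM and 100000 nM, most likely as a limit again.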

Compound 4, half-maximal effective concentration: > 36600 nM
Compound 4 ended at the assay's limit (the forecaster's own chance of this, stated with the estimate: 80%); the middle value sits exactly at the limit.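

For the compounds shown here, compound 3 and compound 4 both give only a limit, and no step between them can be read. The compounds shown leave open whether the added chloro changes anything in this assay, and what concentration any of them needs for the effect.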